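Removing the amine from the crotonamide series

The source may report more compounds than this note shows. Statements on the series, on what has been measured and on what is new or still open speak of the compounds shown alone.

Compound 3 `CN(C)CC/C=C/C(=O)Nc1ccccc1` gives 7.38 h in an ADME assay for pharmacokinetics, read by LC-MS, in phosphate buffer, with a stated time of 120 min, at pH 7.4, tested at 1 uM, in the presence of a further agent that is not named here (on this read-out lower numbers stand for a shorter-lived compound and higher numbers for a longer-lived compound), and stands highest of the two numbers shown there. For the measured compounds named here, its nearest neighbour, compound 1 `O=C(/C=C/CN1CCCCC1)Nc1ccccc1`, gives 2.95 h, and the step of a 2.5-fold higher number from compound 1 to compound 3 (0.40 log units; beyond the scatter) is the only measured step in the set. Compound 2 `C=C(CO)C(=O)Nc1ccccc1` returns > 8.53 h, which is a limit of the assay rather than a number, as recorded in the limit of > 8.53 h in this assay, at which 1 of the 3 values shown sits.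

Compound 4 `C/C=C/C(=O)Nc1ccccc1` is the next member to be measured. It differs from compound 3 as follows: hydrogen in place of (dimethylamino)methyl on a saturated chain carbon bound to a double-bonded chain carbon. Going by the values given here, the one measured step, from compound 1 to compound 3, exchanges one amine for another and so does not speak directly to removing the amine altogether; no measured step does. Among the compounds with values here, compound 2, the only member without an amine, gives a limit. On that basis, compound 4 is expected to show a 1.4-fold higher number from compound 3 to compound 4 (0.13 log units; within the scatter), and its half-life is estimated at 10 h, within 4 h to 25 h, with a real chance that only a limit is reported.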

Compound 4, half-life: > 8.53 h
Compound 4: no number, only a limit; the forecaster's own chance of this, stated with the estimate: 55%; the middle value does not contradict the limit.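

In this assay compound 4 returns > 8.53 h, a limit of the assay and not a number, so a crotonamide carrying no amine at all joins compound 2 at the top of the readable range: the limit of > 8.53 h in this assay, at which 2 of the 4 values shown sit.

Replacing the piperidin-1-yl with hydrogen on the saturated chain carbon gives an at least 2.8-fold higher number from compound 1 to compound 4 (0.46 log units; beyond the scatter), which extends the earlier amine-for-amine step to full removal of the amine. Replacing the (dimethylamino)methyl gives an at least 1.1-fold higher number from compound 3 to compound 4 (0.06 log units; that floor lies within the scatter), so no gain over the dimethylamino member can be claimed, and the step between the two limits cannot be read.

On these data alone, how far compound 4 lies past its limit stays open, and with it the true size of both steps. Also open, as far as these compounds go, is whether a carboxylic acid or a morpholine at this place would give a number or another limit.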